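A few compounds are considered here, and "the series" means these few. Any claim that something is new, unique, unknown or untested is made for them only; others in the source may bear on it.

Going by the values given here, compound 1 `Clc1ccccc1C1Cc2nccn2C1` is the only compound of this pair for which the assay returned an actual number: in a functional assay on CHO cells for agonist activity at Alpha-1D adrenergic receptor (Homo sapiens), read by FLIPR and calcium flux (on this read-out lower numbers stand for an effect already at smaller amounts and higher numbers for an effect only at larger amounts of compound), compound 1 gives 364 nM. Compound 2 `COc1cccc(C2Cc3nccn3C2)c1` was also tested. In this assay compound 2 reaches only > 10000 nM, which is a limit of the assay and not a number. Among the compounds with values here, that is the one piece of evidence beyond the value of compound 1: the limit of > 10000 nM in this assay, at which 1 of the 2 values shown sits. Within the data shown here, no pair of compounds that differ in a single place has been measured, so no measured step is available.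

Compound 3 `COCc1ccccc1C1Cc2nccn2C1` has not been measured in this assay. It differs from compound 1 in one place (methoxymethyl in place of chloro on an aromatic carbon). The chloro group of compound 1 is thus replaced by a methoxymethyl group on the same aromatic carbon. Among the measured compounds shown here, with no measured step to lean on, the size of this change can only be guessed. The step is expected to go toward a weaker effect, with a 4.1-fold higher number from compound 1 to compound 3 (0.61 log units; beyond the scatter) as the estimated shift. Compound 3 is therefore expected to give about 1500 nM in this assay, most likely between 300 nM and 8000 nM.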

Compound 3, half-maximal effective concentration: > 10000 nM
Compound 3 was reported as a limit; the forecaster's own chance of this, stated with the estimate: 25%; middle value at least 6.6-fold (0.82 log units) away from the limit.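

Going by these compounds alone, replacing chloro with methoxymethyl on this aromatic carbon, ortho to a group of 8 heavy atoms, gives the first measured step: an at least 27-fold higher number from compound 1 to compound 3 (1.43 log units; beyond the scatter). Within the data shown here, the position is therefore not indifferent to what sits on it: in this assay, the single chlorine of compound 1 gives a measurable number, whereas the larger group of 3 heavy atoms, which brings 1 hydrogen-bond acceptor, does not. Compound 3 stands at a limit of the assay rather than at a number, so this step shows only the smallest possible size of the change, and the upper limit now holds most of the compounds shown: the limit of > 10000 nM in this assay, at which 2 of the 3 values shown sit.

This single change alters the atom count and adds an oxygen at the same time, so the compounds shown cannot tell which of the two matters, or whether compound 3 has any effect at larger amounts. A fluorine, a bromine, an ethyl group or a methoxy group on the same aromatic carbon would help to separate these possibilities.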